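Piperidin-1-yl in place of (3,4-dimethylphenyl)amino

The source may report more compounds than this note shows. Statements on the series, on what has been measured and on what is new or still open speak of the compounds shown alone.

In a functional assay on ECa-109 cells for inhibition, with ECa-109 cell line (Homo sapiens) as the target, read by sulforhodamine B assay (on this read-out higher numbers stand for weaker inhibition and lower numbers for stronger inhibition), compound 1 `COc1ccccc1NC1=CC(=O)c2nc3n(c2C1=O)[C@H]1OC[C@@H](O)[C@H]1OC3` reads > 4000 nM, which is a limit of the assay and not a number. Among the compounds with values here, compound 2 `Cc1ccc(NC2=CC(=O)c3nc4n(c3C2=O)[C@H]2OC[C@@H](O)[C@H]2OC4)cc1C` gives 2820 nM, the only exact number so far. Compound 3 `O=C1C=C(N2CCCCC2)C(=O)c2c1nc1n2[C@H]2OC[C@@H](O)[C@H]2OC1` differs from it on a double-bonded ring carbon: piperidin-1-yl in place of (3,4-dimethylphenyl)amino on a double-bonded ring carbon. Within the data shown here, the one measured step, an at least 1.4-fold lower number from compound 1 to compound 2 (0.15 log units; that floor lies within the scatter), has a floor within the scatter and exchanges only 2-methoxyphenyl for 3,4-dimethylphenyl, so it does not test this swap and no step beyond the scatter is expected. The estimated step is a 1.2-fold higher number from compound 2 to compound 3 (0.09 log units; within the scatter). For compound 3 the expected value is 3500 nM, with an estimated range from 1200 nM to 10000 nM.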

Compound 3, half-maximal inhibitory concentration: > 8000 nM
Compound 3: only a limit was reported (the forecaster's own chance of this, stated with the estimate: 45%); at least 2.2-fold (0.35 log units) between middle value and limit.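

Within the data shown here, exchanging (3,4-dimethylphenyl)amino for piperidin-1-yl gives an at least 2.8-fold higher number from compound 2 to compound 3 (0.45 log units; beyond the scatter), the first change in this assay that lies beyond the scatter, so the group on this double-bonded ring carbon does affect the read-out. The reading for compound 3 is a limit and not a number: the limit of > 8000 nM in this assay, at which 1 of the 3 values shown sits.
Compound 1 also reads as a limit, so the step from it to compound 3 cannot be read.

From the compounds shown here alone, this swap removes the aromatic ring and the hydrogen-bond donor together, so which loss counts stays open. A cyclohexylamino group, which keeps the donor on a non-aromatic ring, would help separate the two.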